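The compounds below may be only part of what the source reports. "The series", "measured", "known", "first", "only" and "open" are said of these compounds alone.

In a functional assay on P388 cells (Mus musculus) for cytotoxicity (a lower number here means a stronger inhibitor, a higher number a weaker inhibitor), three compounds sharing one core have been measured, and they differ only in the substituted phenyl on a saturated chain carbon. Compound 1 `Cc1cc(-c2c(F)cc3c(=O)c(Cc4cccc(O)c4)cn(C4CC4)c3c2F)cc(C)n1`, with a 3-hydroxyphenyl, gives 2200 nM. Compound 2 `COc1cccc(Cc2cn(C3CC3)c3c(F)c(-c4cc(C)nc(C)c4)c(F)cc3c2=O)c1`, with a 3-methoxyphenyl, gives 20000 nM. Compound 3 `Cc1cc(-c2c(F)cc3c(=O)c(Cc4c(O)cccc4O)cn(C4CC4)c3c2F)cc(C)n1`, with a 2,6-dihydroxyphenyl, gives 250 nM, the lowest number of the three and so the strongest inhibitor among them.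

Compound 4 `Cc1cc(-c2c(F)cc3c(=O)c(Cc4ccc(Cl)cc4)cn(C4CC4)c3c2F)cc(C)n1` changes this group: 4-chlorophenyl in place of 2,6-dihydroxyphenyl on a saturated chain carbon bound to an aromatic carbon. Among the compounds with values here, three measured steps bear on the change. Putting methyl on the hydroxy oxygen gave a 9.1-fold higher number from compound 1 to compound 2 (0.96 log units; beyond the scatter), a modest step. The 2,6-dihydroxyphenyl gave an 8.8-fold lower number from compound 1 to compound 3 (0.94 log units; beyond the scatter), also modest, and an 80-fold lower number from compound 2 to compound 3 (1.90 log units; beyond the scatter), a large one. Across these compounds, the number rises as free hydroxy groups are lost, and none goes against this. Like compound 2, compound 4 has no hydroxy group, although no measured compound carries chlorine, so the comparison is loose. A large rise is therefore expected, estimated as a 24-fold higher number from compound 3 to compound 4 (1.38 log units; beyond the scatter). Compound 4 is expected near 6000 nM, within an estimated range of 1200 nM to 30000 nM.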

Compound 4, half-maximal inhibitory concentration: 20000 nM
Estimate against measurement, compound 4: 3.3-fold (0.52 log units) below; measured number inside the range.
By their numbers in this assay, from the lowest: compound 3; then compound 1; then compounds 2 and 4 (each within the scatter of the next).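

In this assay, replacing the 2,6-dihydroxyphenyl with a 4-chlorophenyl gave an 80-fold higher number from compound 3 to compound 4 (1.90 log units; beyond the scatter) and so extends the pattern to a group carrying chlorine: the number again rises when free hydroxy groups are lost, and none of the four compounds goes against this. Two rings without a hydroxy group, the 4-chlorophenyl and the 3-methoxyphenyl, also cannot be told apart here, with no change at the digits printed from compound 2 to compound 4 (within the scatter) as the result. Within the data shown here, the single hydroxy group of compound 1 still counts for something, as a 9.1-fold higher number from compound 1 to compound 4 (0.96 log units; beyond the scatter) shows.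

No evidence at hand explains these differences. The compounds shown leave open whether an amine or a carboxylic acid on this ring could match the hydroxy groups, and whether a 2-hydroxyphenyl alone would match the 2,6-dihydroxyphenyl.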